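The source may report more compounds than this note shows. Statements on the series, on what has been measured and on what is new or still open speak of the compounds shown alone.

Working notes on the series. For the measured compounds named here, compound 2 `COc1cc(-c2nn(-c3cccc(NC(=O)c4cccc(C(F)(F)F)c4)c3)cc2-c2ccncc2)ccc1Cl` gives 1660 nM in a functional assay on KM12 cells (Homo sapiens) for inhibition, read by sulforhodamine B assay, with a stated time of 48 h (a higher number here means a weaker inhibitor, a lower number a stronger inhibitor), the highest of the three numbers measured so far. Compound 1 `O=C(Nc1cccc(-n2cc(-c3ccncc3)c(-c3ccc(Cl)c(O)c3)n2)c1)Nc1cccc(C(F)(F)F)c1` gives 1330 nM in this assay, and compound 3 `O=C(Nc1cccc(-n2cc(-c3ccncc3)c(-c3ccc(Cl)c(O)c3)n2)c1)Nc1ccc(Cl)c(Cl)c1` gives 1010 nM. All three numbers lie within the scatter of one another, so no order among them can be read. Going by the values given here, the single measured step, a 1.3-fold lower number from compound 1 to compound 3 (0.12 log units; within the scatter), exchanges the aryl group on an amide-type nitrogen and leaves the number essentially where it was.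

Compound 4 `COc1cc(-c2nn(-c3cccc(NC(=O)Nc4cccc(C(F)(F)F)c4)c3)cc2-c2ccncc2)ccc1Cl` is not yet measured. It differs from compound 2 by (3-(trifluoromethyl)phenyl)amino in place of 3-(trifluoromethyl)phenyl on a carbonyl carbon, with everything else in compound 2 kept. Among the compounds with values here, no measured step covers this kind of change on the carbonyl carbon, so there is no direct precedent. What the measured compounds do show is that compound 1, which carries the same (3-(trifluoromethyl)phenyl)amino group on its carbonyl carbon, gives 1330 nM, and that the step of a 1.3-fold lower number from compound 1 to compound 3 (0.12 log units; within the scatter) changed nothing beyond the scatter. For compound 4 the expected step is therefore a 1.2-fold lower number from compound 2 to compound 4 (0.07 log units; within the scatter), that is no shift beyond the scatter. Compound 4 is estimated at 1400 nM in this assay, with a range from 600 nM to 3500 nM.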

Compound 4, half-maximal inhibitory concentration: 570 nM
For compound 4 the middle estimate is 2.5-fold (0.39 log units) above the measured one, and the stated range ends above it.
By their numbers in this assay, from the lowest: compounds 4, 3, 1 and 2 (each within the scatter of the next, the first and the last beyond it).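

In this assay, for the compounds shown here, the exchange on the carbonyl carbon, (3-(trifluoromethyl)phenyl)amino in place of 3-(trifluoromethyl)phenyl, gives a 2.9-fold lower number from compound 2 to compound 4 (0.46 log units; beyond the scatter) and so moves the number at a place where the earlier compounds offered no step at all. Going by these compounds alone, the oxygen on the aromatic ring also proves responsive, since methyl in place of hydrogen there gives a 2.3-fold lower number from compound 1 to compound 4 (0.37 log units; beyond the scatter) while the aryl exchange on the amide-type nitrogen, a 1.3-fold lower number from compound 1 to compound 3 (0.12 log units; within the scatter) stayed without effect; both new steps are modest, and they meet in compound 4, the only compound here with both the methyl on that oxygen and the amino-linked carbonyl group. The series holds no measurement that could explain either step.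

Whether the carbonyl-carbon change gives a step of similar size with hydrogen on the oxygen remains open, as the compounds shown include no partner for compound 1 with 3-(trifluoromethyl)phenyl on its carbonyl carbon. Also open, on these data alone, is how the number responds to an ethyl group or a longer chain on that oxygen, or to a methylene group in place of the amino link on the carbonyl carbon.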